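This account rests on a few compounds, and the source may have more. Where it says the series, first, only, none or still open, it means among the compounds named here.

Measured compounds and values:
- Compound 3, `COc1ccc(/C=C\C(=O)O)c(OCc2cn(-c3ccccc3)nn2)c1CC=C(C)C`: 35000 nM
- Compound 1, `COc1ccc(/C=C\C(=O)O)c(OCc2cn(-c3ccccc3I)nn2)c1CC=C(C)C`: "not determined" (no result reported)
- Compound 2, `COc1ccc(-n2cc(COc3c(/C=C\C(=O)O)ccc(OC)c3CC=C(C)C)nn2)cc1`: "not determined" (no result reported)

All three share one core, and they differ only in the group carried on a nitrogen of the five-membered ring. Going by the values given here, in a functional assay on PC-3 cells (Homo sapiens) for cytotoxicity, read by MTT assay, with a stated time of 24 h (a higher number here means a weaker inhibitor, a lower number a stronger inhibitor), compound 3 gives 35000 nM, a weak value, and it is the only number in the set: compound 1 gives "not determined" (no result reported) and compound 2 gives "not determined" (no result reported), so nothing can be said of how their changes shift the reading.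

Compound 4, `COc1ccc(/C=C\C(=O)O)c(OCc2cn(-c3cccc([N+](=O)[O-])c3)nn2)c1CC=C(C)C`, has not yet been measured in this assay. It differs from compound 3 in one place:

nitro in place of hydrogen on an aromatic carbon

Among the compounds with values here, no pair of measured compounds shows what a change of this kind does in this assay. Within the data shown here, there is no step to lean on. Among the measured compounds shown here, the expectation for compound 4 is therefore anchored on the one number available, that of compound 3, and the step of a 1.2-fold lower number from compound 3 to compound 4 (0.07 log units; within the scatter) is expected to be small, not clearly beyond the scatter in either direction. In this assay compound 4 is estimated to give 30000 nM, with a likely range from 10000 nM to 90000 nM.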

Compound 4, half-maximal inhibitory concentration: 42100 nM
Compound 4: middle estimate off by 1.4-fold (0.15 log units), on the low side; the range from low to high includes it.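

At this spot on the six-membered aromatic ring, meta to a large group, the change from phenyl to 3-nitrophenyl adds three heavy atoms and two hydrogen-bond acceptors, and in this assay it comes to a step that stays small (a 1.2-fold higher number from compound 3 to compound 4 (0.08 log units; within the scatter)). Going by these compounds alone, this is the first pair in the set with a number on both sides, so it gives the first direct reading of a change on this ring: here, a nitro group in place of hydrogen leaves the two compounds indistinguishable in this cell assay. No supporting measurement bears on why the reading behaves this way.

One pair at one position cannot show whether this ring tolerates substitution in general, since a single nitro group speaks only for itself and both values remain weak. On these data alone, it remains open whether an amine or a carboxylic acid at the same spot, or a nitro group elsewhere on the ring, would move the number beyond the usual scatter of repeated measurements.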